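The source may report more compounds than this note shows. Statements on the series, on what has been measured and on what is new or still open speak of the compounds shown alone.

Working notes on the series. In a functional assay on HeLa cells (Homo sapiens) for antiproliferative activity, with a stated time of 24 h (a higher number here means a weaker inhibitor, a lower number a stronger inhibitor), compound 1 `NC(=O)c1c(NC(=O)c2ccccc2F)sc2c1CCN(Cc1ccc(Cl)cc1Cl)C2` gives 27500 nM. In this assay compound 3 `NC(=O)c1c(NC(=O)c2ccccc2F)sc2c1CCN(C(=S)Nc1ccccc1Cl)C2` gives 19400 nM; compound 1 and compound 3 are the only two numbers shown and sit within the scatter of each other. In this assay compound 2 `NC(=O)c1c(NC(=O)c2ccccc2)sc2c1CCN(C(=S)Nc1ccccc1Cl)C2` gives only a limit, > 50000 nM. The step of a 1.4-fold lower number from compound 1 to compound 3 (0.15 log units; within the scatter) is within the scatter. The step of an at least 2.5-fold lower number from compound 2 to compound 3 (0.41 log units; beyond the scatter) is at least modest and rests on (the limit of > 50000 nM in this assay, at which 1 of the 3 values shown sits).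

Compound 4 `NC(=O)c1c(NC(=O)c2ccccc2Br)sc2c1CCN(C(=S)Nc1ccccc1Cl)C2` differs from compound 3 by bromo in place of fluoro on an aromatic carbon. Within the data shown here, only an at least 2.5-fold lower number from compound 2 to compound 3 (0.41 log units; beyond the scatter) bears on this position, and it shows fluoro in place of hydrogen lowering the number; no measured step compares two halogens with each other. The expected change is therefore small, a 1.3-fold lower number from compound 3 to compound 4 (0.11 log units; within the scatter), with compound 4 estimated to stay near compound 3 in this assay. Compound 4 is estimated at 15000 nM, with a range from 5000 nM to 45000 nM.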

Compound 4, half-maximal inhibitory concentration: 46900 nM
Compound 4: middle estimate off by 3.1-fold (0.50 log units), on the low side; measured number above the stated range.
By their numbers in this assay, from the lowest: compounds 3, 1 and 4 (each within the scatter of the next, the first and the last beyond it). At a limit, above all of these: compound 2.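

In this assay, among these compounds, bromo in place of fluoro gives a 2.4-fold higher number from compound 3 to compound 4 (0.38 log units; beyond the scatter), the first direct comparison of two halogens at this place, and it shows that 2-fluorophenyl and 2-bromophenyl are not interchangeable here. The lowering seen with fluoro in place of hydrogen, an at least 2.5-fold lower number from compound 2 to compound 3 (0.41 log units; beyond the scatter), therefore does not extend to every halogen in this pair of changes. Bromo in place of hydrogen gives an at least 1.0-fold lower number from compound 2 to compound 4 (0.02 log units; that floor lies within the scatter), a floor that rests on a limit: the limit of > 50000 nM in this assay, at which 1 of the 4 values shown sits.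

The compounds shown hold only hydrogen, fluoro and bromo at this place, so it remains open where chloro, methyl or methoxy would fall, and nothing here gives a cause for the rise. Going by these compounds, it also remains open whether bromo in place of fluoro acts the same way with the group that compound 1 carries on the ring amine nitrogen.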